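Swapping Phenyl for Chloropyridinyl on the Amide Nitrogen

This account rests on a few compounds, and the source may have more. Where it says the series, first, only, none or still open, it means among the compounds named here.

Three compounds sharing one core differ only in the group on the amide nitrogen. Compound 1 `CCCNC(=O)c1ccc(Oc2nc(-c3c(C)noc3C)cnc2N)cc1` gives 32100 nM in a functional assay on HeLa cells (Homo sapiens) for inhibition, read by MTT assay, with a stated time of 72 h; a lower number here means a stronger inhibitor, a higher number a weaker inhibitor. Compound 2 `Cc1noc(C)c1-c1cnc(N)c(Oc2ccc(C(=O)NC3CC3)cc2)n1` gives 17800 nM, and compound 3 `Cc1noc(C)c1-c1cnc(N)c(Oc2ccc(C(=O)Nc3ccccc3)cc2)n1` gives 10500 nM, the lowest of the three numbers. The step of a 3.1-fold lower number from compound 1 to compound 3 (0.49 log units; beyond the scatter) lies beyond the scatter, whereas a 1.8-fold lower number from compound 1 to compound 2 (0.26 log units; within the scatter) and a 1.7-fold lower number from compound 2 to compound 3 (0.23 log units; within the scatter) lie within it. Compound 4 `Cc1noc(C)c1-c1cnc(N)c(Oc2ccc(C(=O)Nc3cccc(Cl)n3)cc2)n1` carries 6-chloropyridin-2-yl in place of phenyl on an amide-type nitrogen. The measured steps compare only a chain, a small ring and phenyl at that nitrogen; none exchanges one aromatic ring for another, so they show merely that changes here have stayed small. A step of modest size at most is therefore expected, in either direction. Compound 4 is estimated at 7000 nM, between 2500 nM and 20000 nM. That would be an expected step of a 1.5-fold lower number from compound 3 to compound 4 (0.18 log units; within the scatter).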

Compound 4, half-maximal inhibitory concentration: 25500 nM
Estimate against measurement, compound 4: 3.6-fold (0.56 log units) below, and the stated range ends below it.
By their numbers in this assay, from the lowest: compounds 3, 2, 4 and 1 (each within the scatter of the next, the first and the last beyond it).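

In this assay, among the compounds shown here, this is the first exchange of one aromatic ring for another on the amide nitrogen, and 6-chloropyridin-2-yl in place of phenyl gives a 2.4-fold higher number from compound 3 to compound 4 (0.39 log units; beyond the scatter), so an aromatic ring here does not by itself bring a lower number. Against the non-aromatic groups, the values stay within the scatter, with a 1.4-fold higher number from compound 2 to compound 4 (0.16 log units; within the scatter) and a 1.3-fold lower number from compound 1 to compound 4 (0.10 log units; within the scatter). No measurement shown accounts for the step.

From the compounds shown here alone, whether the step follows the ring nitrogen or the chlorine remains open. A plain pyridin-2-yl or a chlorophenyl group on the same nitrogen would separate the two.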